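Swapping a nitrophenyl for a methoxynaphthyl on the core

The compounds below may be only part of what the source reports. "The series", "measured", "known", "first", "only" and "open" are said of these compounds alone.

Compound 3 `N#CC1=C(N)N(c2ccc(S(N)(=O)=O)cc2)C2=C(C(=O)CCC2)C1c1cccc([N+](=O)[O-])c1` gives 25 ug/mL in a functional assay on Ehrlich cells (Mus musculus) for antiproliferative activity, read by trypan blue exclusion, with a stated time of 2 h; on this read-out lower numbers stand for stronger inhibition and higher numbers for weaker inhibition. That places compound 3 level with compound 2 `COc1ccc(C2C(C#N)=C(N)N(c3ccc(S(N)(=O)=O)cc3)C3=C2C(=O)CCC3)cc1`, which gives 25 ug/mL, the two together holding the highest number of the three, while compound 1 `N#CC1=C(N)N(c2ccc(S(N)(=O)=O)cc2)C2=C(C(=O)CCC2)C1c1ccc(O)cc1` gives 3 ug/mL. The change to compound 4 `COc1ccc(C2C(C#N)=C(N)N(c3ccc(S(N)(=O)=O)cc3)C3=C2C(=O)CCC3)c2ccccc12` is 4-methoxynaphthalen-1-yl in place of 3-nitrophenyl on a saturated ring carbon. The measured steps that bear on it are no change at the digits printed from compound 2 to compound 3 (within the scatter), alongside an 8.3-fold higher number from compound 1 to compound 3 (0.92 log units; beyond the scatter) and an 8.3-fold higher number from compound 1 to compound 2 (0.92 log units; beyond the scatter). The group entering compound 4 carries the same methoxy group that compound 2 has, and compound 2 gives 25 ug/mL, so no step beyond the scatter is expected, namely no change at the digits printed from compound 3 to compound 4 (within the scatter). Compound 4 is accordingly estimated at 25 ug/mL, within a range from 8 ug/mL to 80 ug/mL.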

Compound 4, half-maximal inhibitory concentration: 70 ug/mL
The estimate for compound 4 lay 2.8-fold (0.45 log units) below the measured number, within the range that was stated.
By their numbers in this assay, from the lowest: compound 1; then compounds 2 and 3 (each within the scatter of the next); then compound 4.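

The methoxy group alone does not set the level at this position: with it kept, adding the second aromatic ring of 4-methoxynaphthalen-1-yl gives a 2.8-fold higher number from compound 2 to compound 4 (0.45 log units; beyond the scatter), and on this read-out a higher number means weaker inhibition. Replacing 3-nitrophenyl gives the same result, a 2.8-fold higher number from compound 3 to compound 4 (0.45 log units; beyond the scatter), while the gap from 4-hydroxyphenyl widens to a 23-fold higher number from compound 1 to compound 4 (1.37 log units; beyond the scatter). Nothing measured here explains this loss.

Still open, from the compounds shown here alone, is whether 4-hydroxynaphthalen-1-yl, carrying a hydroxyl in place of the methoxy, would restore the level of compound 1. A 4-aminophenyl or 4-carboxyphenyl group on this carbon also remains untested among the compounds shown.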